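Swapping the halogenated phenyl for a methylphenyl

The source may hold more compounds than are shown below. What is called first, only, known or untested is meant among the compounds shown, and "the series" means these compounds.

Three measured compounds share one core and differ only in the aryl group on an aromatic nitrogen. In a functional assay on SGC-7901 cells (Homo sapiens) for inhibition, read by MTT assay, with a stated time of 24 h (a lower number here means a stronger inhibitor, a higher number a weaker inhibitor), compound 1 `CC1(C)[C@H]2CC[C@]1(C)N(Cc1cn(-c3cccc(Cl)c3)nn1)C(=O)C2` gives 510 nM. Compound 2 `CC1(C)[C@H]2CC[C@]1(C)N(Cc1cn(-c3ccccc3Br)nn1)C(=O)C2` gives 500 nM in this assay, and compound 3 `CC1(C)[C@H]2CC[C@]1(C)N(Cc1cn(-c3ccccc3F)nn1)C(=O)C2` gives 300 nM. Compound 3 holds the lowest of the three numbers, yet its steps to both others lie within the scatter: a 1.7-fold lower number from compound 1 to compound 3 (0.23 log units; within the scatter) and a 1.7-fold lower number from compound 2 to compound 3 (0.22 log units; within the scatter). The remaining step, a 1.0-fold lower number from compound 1 to compound 2 (0.01 log units; within the scatter), is likewise within the scatter.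

Compound 4 `Cc1cccc(-n2cc(CN3C(=O)C[C@@H]4CC[C@@]3(C)C4(C)C)nn2)c1` has not yet been measured in this assay. It differs from compound 3 in one place: 3-methylphenyl in place of 2-fluorophenyl on an aromatic nitrogen. All three measured steps bear on this change, since each of them also exchanged the group on that aromatic nitrogen, and none of them moved the number beyond the scatter, whether the group was 3-chlorophenyl, 2-bromophenyl or 2-fluorophenyl. Among the compounds with values here, no measured compound carries a methyl-bearing phenyl, so nothing is known about that group itself. On this basis compound 4 is expected to show no step beyond the scatter, a 1.3-fold higher number from compound 3 to compound 4 (0.12 log units; within the scatter). The estimate for compound 4 in this assay is 400 nM, with a range from 200 nM to 900 nM.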

Compound 4, half-maximal inhibitory concentration: 410 nM
Compound 4: middle estimate off by 1.0-fold (0.01 log units), on the low side; the measured number falls inside the stated range.
By their numbers in this assay, from the lowest: compounds 3, 4, 2 and 1 (each within the scatter of the next).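

In this assay, a methyl-bearing phenyl on the aromatic nitrogen gives no step beyond the scatter from any of the halogenated phenyl groups: a 1.4-fold higher number from compound 3 to compound 4 (0.14 log units; within the scatter), a 1.2-fold lower number from compound 2 to compound 4 (0.09 log units; within the scatter), and a 1.2-fold lower number from compound 1 to compound 4 (0.09 log units; within the scatter). Within the data shown here, the last of these is the only step that exchanges a halogen for methyl on an aromatic carbon while leaving the rest of the compound unchanged, and it shows that a halogen on this phenyl is not required for a number in this range. All four compounds now lie within the scatter of one another, so this position has so far shown no measurable preference among these aryl groups, and no measurement offered here accounts for that flatness.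

The compounds leave open whether the number would stay in this range with an amine or a carboxylic acid on the phenyl, or with a pyridine ring or a longer alkyl chain in its place. From the compounds shown here alone, they also do not show whether an unsubstituted phenyl would give a similar number, so the contribution of any substituent on this ring remains unknown.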